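From 2-Fluorophenyl to 4-Chlorophenyl: A Step Without Direct Precedent

This account rests on a few compounds, and the source may have more. Where it says the series, first, only, none or still open, it means among the compounds named here.

Three related compounds have been measured so far in a functional assay on MCF7 cells (Homo sapiens) for inhibition, read by MTT assay, with a stated time of 72 h; a lower number here means a stronger inhibitor, a higher number a weaker inhibitor. Compound 1 `C/C1=C\CC[C@@]2(C)O[C@@H]2[C@H]2OC(=O)[C@@H](CN3CCN(c4ccccc4)CC3)[C@@H]2C[C@H]1O` gives 19000 nM, compound 2 `C[C@]12O[C@@H]1CC[C@@]1(C)O[C@@H]1[C@H]1OC(=O)[C@@H](CN3CCN(c4ccccc4)CC3)[C@@H]1C[C@H]2O` gives 59000 nM, and compound 3 `C[C@]12O[C@@H]1CC[C@@]1(C)O[C@@H]1[C@H]1OC(=O)[C@@H](CN3CCN(c4ccccc4F)CC3)[C@@H]1C[C@H]2O` gives 20000 nM. Compound 3 therefore sits level with compound 1, within the usual scatter, while compound 2 is the weaker inhibitor of that pair.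

The next compound, compound 4 `C[C@]12O[C@@H]1CC[C@@]1(C)O[C@@H]1[C@H]1OC(=O)[C@@H](CN3CCN(c4ccc(Cl)cc4)CC3)[C@@H]1C[C@H]2O`, shares the core of compound 3 and differs only in its aromatic group, with 4-chlorophenyl in place of 2-fluorophenyl on an amine nitrogen in a ring.

Among the measured compounds shown here, one measured step bears on this change: a 3.0-fold lower number from compound 2 to compound 3 (0.47 log units; beyond the scatter). There, fluoro replaced hydrogen on an aromatic carbon, and the modest step lay beyond the scatter. For the measured compounds named here, it offers only a rough guide, since no measured compound carries chlorine. Compound 4 still has a halogen on its phenyl group, so the closest comparison is compound 3 at 20000 nM. The step expected in this assay is no change at the digits printed from compound 3 to compound 4 (within the scatter), which would lie within the scatter. For compound 4, the estimated value is 20000 nM, with an expected range from 8000 nM to 50000 nM.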

Compound 4, half-maximal inhibitory concentration: 29000 nM
Beside the measured number, compound 4's estimate is 1.5-fold (0.16 log units) below it; low and high end bracket the measured number.
By their numbers in this assay, from the lowest: compounds 1, 3 and 4 (each within the scatter of the next); then compound 2.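

Changing 2-fluorophenyl to 4-chlorophenyl gives a 1.5-fold higher number from compound 3 to compound 4 (0.16 log units; within the scatter), so this assay does not separate these two halogen-bearing phenyl groups on the ring nitrogen. Compared with the plain phenyl group of compound 2, chloro in place of hydrogen gives a 2.0-fold lower number from compound 2 to compound 4 (0.31 log units; beyond the scatter), a modest step beyond the scatter, and this adds a second halogen example alongside a 3.0-fold lower number from compound 2 to compound 3 (0.47 log units; beyond the scatter); on this shared core, both halogen-bearing compounds have lower numbers than compound 2, although all three values remain high. No measurement offered here explains these steps.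

Compound 3 and compound 4 differ in both the halogen and its place on the phenyl group, so their comparison cannot show what either change does alone. The compounds shown also leave open whether the lower number depends on a halogen at all, or whether a methoxy group or a nitrile on the phenyl group would give a similar step from compound 2.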